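Replacing one aromatic group in compound 2

The compounds below may be only part of what the source reports. "The series", "measured", "known", "first", "only" and "open" are said of these compounds alone.

Measured in a functional assay on HepG2 cells (Homo sapiens) for cytotoxicity, read by sulforhodamine B assay, with a stated time of 48 h (a higher number here means a weaker inhibitor, a lower number a stronger inhibitor), so far:
compound 1 `COc1ccc(/C=C/C(=O)c2ccc(N)c(-c3ccc(F)cc3)c2)cc1O` gives "not determined" (no result reported)
compound 2 `COc1ccc(-c2cc(C(=O)/C=C/c3cc(OC)c(OC)c(OC)c3)ccc2N)cc1OC` gives 2680 nM
compound 3 `COc1ccc(-c2cc(C(=O)/C=C/c3cccc(OC)c3OC)ccc2N)cc1OC` gives 5360 nM

Among the compounds with values here, compound 1 has no number, so only two compounds can be compared. Compound 2 (2680 nM) and compound 3 (5360 nM) lie within the usual scatter of each other, so neither stands apart. Compound 4 `COc1cc(/C=C/C(=O)c2ccc(N)c(-c3ccc(F)cc3)c2)cc(OC)c1OC` carries 4-fluorophenyl in place of 3,4-dimethoxyphenyl on an aromatic carbon and otherwise matches compound 2. Within the data shown here, no measured pair shows this swap, so the data offer little guidance. Only a small change is expected: the estimated 1.1-fold higher number from compound 2 to compound 4 (0.05 log units; within the scatter) stays within the scatter in this assay with no firm direction. For compound 4 the expected value is 3000 nM with an estimated range from 900 nM to 10000 nM as the likely span.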

Compound 4, half-maximal inhibitory concentration: 4210 nM
The estimate for compound 4 lay 1.4-fold (0.15 log units) below the measured number; the measured number falls inside the stated range.
By their numbers in this assay, from the lowest: compounds 2, 4 and 3 (each within the scatter of the next).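

Putting 4-fluorophenyl in place of 3,4-dimethoxyphenyl gives a 1.6-fold higher number from compound 2 to compound 4 (0.20 log units; within the scatter) in this assay and so stays within the scatter. On this aromatic carbon, ortho to an amino group, a group with fewer heavy atoms and no hydrogen-bond acceptors therefore leaves the number close to that of compound 2. No supporting measurement explains this result.

A single swap cannot separate the loss of the two methoxy groups from the gain of fluorine. On these data alone, how an unsubstituted phenyl, a carboxylic acid or an amine would behave on this carbon stays open.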